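Two Chlorines Exchanged for Two Fluorines

This account rests on a few compounds, and the source may have more. Where it says the series, first, only, none or still open, it means among the compounds named here.

Compound 1 `COc1cc(-c2cc(/C=C/C(=O)c3ccc(Cl)c(Cl)c3)[nH]n2)cc(OC)c1OC`: 1720 nM
Compound 2 `COc1cc(C(=O)/C=C/c2cc(-c3cc(OC)c(OC)c(OC)c3)n[nH]2)cc(OC)c1OC`: 1460 nM

In a functional assay on HOP-62 cells (Homo sapiens) for inhibition, read by sulforhodamine B assay, with a stated time of 48 h (a lower number here means a stronger inhibitor of growth, a higher number a weaker inhibitor of growth), compound 1 gives 1720 nM, the higher of the two numbers shown, while compound 2 gives 1460 nM; the two lie within the usual scatter of each other, so neither can be called the stronger. Compound 3 `COc1cc(-c2cc(/C=C/C(=O)c3ccc(F)c(F)c3)[nH]n2)cc(OC)c1OC` differs from compound 1 by 3,4-difluorophenyl in place of 3,4-dichlorophenyl on a carbonyl carbon. Among the measured compounds shown here, no measured pair shows the effect of this change, so only a modest shift is expected, if any, with a slight lean toward weaker growth inhibition. Compound 3 is therefore estimated at 2500 nM, between 1000 nM and 6500 nM. That estimate means a step of a 1.5-fold higher number from compound 1 to compound 3 (0.16 log units; within the scatter), expected to stay near the scatter.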

Compound 3, concentration for 50% growth inhibition: 4390 nM
Estimate against measurement, compound 3: 1.8-fold (0.24 log units) below; the measured number falls inside the stated range.
By their numbers in this assay, from the lowest: compounds 2 and 1 (each within the scatter of the next); then compound 3.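

In this assay the exchange of 3,4-dichlorophenyl for 3,4-difluorophenyl on a carbonyl carbon gives a 2.6-fold higher number from compound 1 to compound 3 (0.41 log units; beyond the scatter) and so shows that this place is sensitive to which halogen the ring carries. The ring itself and the number of heavy atoms stay the same, so exchanging the two halogen atoms alone is enough to weaken growth inhibition. Nothing measured here explains why this happens. As far as these compounds go, whether 3,4-dibromophenyl or a plain phenyl ring at this place would give a lower or a higher number remains open. So does whether a single chlorine would be enough.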